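Replacing piperazin-2-yl with 1-cyclopropylpiperidin-4-yl

The source may report more compounds than this note shows. Statements on the series, on what has been measured and on what is new or still open speak of the compounds shown alone.

Measured in a functional assay on A-375 cells (Homo sapiens) for inhibition, read by MTT assay, with a stated time of 5 days; a higher number here means a weaker inhibitor, a lower number a stronger inhibitor:
- compound 1 `Nc1nccc(-c2sc(C3CCN3)nc2-c2cccc(NS(=O)(=O)c3cc(F)ccc3F)c2F)n1`: 32.8 nM
- compound 2 `Nc1nccc(-c2sc(C3CNCCN3)nc2-c2cccc(NS(=O)(=O)c3cc(F)ccc3F)c2F)n1`: 127 nM

For the measured compounds named here, of these two, compound 2 stands at the higher number, 127 nM, and its only neighbour is compound 1. Going by the values given here, the single measured step is a 3.9-fold higher number from compound 1 to compound 2 (0.59 log units; beyond the scatter). It is modest but beyond the scatter, and it came from piperazin-2-yl in place of azetidin-2-yl on an aromatic carbon.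

Compound 3 `Nc1nccc(-c2sc(C3CCN(C4CC4)CC3)nc2-c2cccc(NS(=O)(=O)c3cc(F)ccc3F)c2F)n1` has not yet been measured in this assay. It carries 1-cyclopropylpiperidin-4-yl in place of piperazin-2-yl on that same aromatic carbon, and the difference counts as 1-cyclopropylpiperidin-4-yl in place of piperazin-2-yl on an aromatic carbon.

Among the compounds with values here, no measured step covers this exact change, so the evidence is thin. The nearest guide is a 3.9-fold higher number from compound 1 to compound 2 (0.59 log units; beyond the scatter), which altered the group at the same place, and a step of no more than that modest size is therefore expected. Within the data shown here, with compound 2 at 127 nM as the higher of only two numbers, a move downward is weakly favoured, though the data do not settle the direction. The expected change is a 2.1-fold lower number from compound 2 to compound 3 (0.33 log units; beyond the scatter). Compound 3 is estimated at 60 nM, with an expected range from 15 nM to 220 nM.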

Compound 3, half-maximal inhibitory concentration: 1.68 nM
The estimate for compound 3 lay 36-fold (1.55 log units) above the measured number; the measured number lies below the stated range.
By their numbers in this assay, from the lowest: compound 3; then compound 1; then compound 2.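

In this assay, the substituent on the aromatic carbon of the five-membered aromatic ring with 1 nitrogen and 1 sulfur turns out to have a much larger effect than the earlier pair showed: 1-cyclopropylpiperidin-4-yl in place of piperazin-2-yl gives a 76-fold lower number from compound 2 to compound 3 (1.88 log units; beyond the scatter), whereas the earlier change of group gave only a 3.9-fold higher number from compound 1 to compound 2 (0.59 log units; beyond the scatter). The same group in place of azetidin-2-yl gives a 20-fold lower number from compound 1 to compound 3 (1.29 log units; beyond the scatter), so compound 3 has the lowest number of the three, with its steps to both others beyond the scatter, and this site accepts a group of 9 heavy atoms carrying an added three-membered ring without any loss in this read-out. Nothing available here accounts for this gain in terms of a measured property.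

From the compounds shown here alone, what a methyl or an acetyl group on the piperidine nitrogen would do in place of the cyclopropyl remains open, as does the effect of a free piperidin-4-yl, so the step cannot yet be divided between the six-membered ring and the cyclopropyl. Going by these compounds, the order of the three compounds also rests on this assay alone, and whether it holds in any other test stays unknown.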